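Dichlorotriazine anilines and a bromo replacement

The compounds below may be only part of what the source reports. "The series", "measured", "known", "first", "only" and "open" are said of these compounds alone.

Measured compounds:
compound 1 `CC(C)(C)c1ccccc1Nc1nc(Cl)nc(Cl)n1` — -4.16%
compound 2 `CCc1ccccc1Nc1nc(Cl)nc(Cl)n1` — -2.26%
compound 3 `OCCc1ccccc1Nc1nc(Cl)nc(Cl)n1` — -11%

In an assay for inhibition of Pro-cathepsin H (Homo sapiens), read by fluorescence, tested at 50 uM (a higher number here means more inhibition at the concentration tested (going by the name of the read-out), a lower number less inhibition), compound 1 gives -4.16%, compound 2 gives -2.26% and compound 3 gives -11%. None of the three separates from the others: a number 1.9 percentage points higher from compound 1 to compound 2 (within the scatter), a number 6.8 percentage points lower from compound 1 to compound 3 (within the scatter) and a number 8.7 percentage points lower from compound 2 to compound 3 (within the scatter) all stay within the scatter, so compound 3 stands among numbers that cannot be told apart, all near zero inhibition.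

Compound 4 `Clc1nc(Cl)nc(Nc2ccccc2Br)n1` differs from compound 3 in one place: bromo in place of 2-hydroxyethyl on an aromatic carbon. The step that bears most on it is the one in which a hydroxy entered, a number 8.7 percentage points lower from compound 2 to compound 3 (within the scatter), and the step from the tert-butyl analogue, a number 6.8 percentage points lower from compound 1 to compound 3 (within the scatter); both were within the scatter. Since every change at this position has left this assay essentially unmoved, no step beyond the scatter is expected for compound 4 either, that is a number 8 percentage points higher from compound 3 to compound 4 (within the scatter). Compound 4 is therefore estimated at -3%, with a range from -15% to 9%, once its measurement is known.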

Compound 4, a percentage reported as inhibition, at one concentration (the size of the read-out at that concentration, not a potency): 4.52%
Compound 4: middle estimate off by 7.5 percentage points, on the low side; low and high end bracket the measured number.
By their numbers in this assay, from the lowest: compounds 3, 1, 2 and 4 (each within the scatter of the next, the first and the last beyond it).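

In this assay, this position now shows its first step beyond the scatter, a number 15.5 percentage points higher from compound 3 to compound 4 (beyond the scatter), a modest one that sets bromo apart from 2-hydroxyethyl on this aromatic carbon. Bromo does not separate from the two alkyl groups, since a number 6.8 percentage points higher from compound 2 to compound 4 (within the scatter) and a number 8.7 percentage points higher from compound 1 to compound 4 (within the scatter) both stay within the scatter, so the separation rests on the pair of compound 3 and compound 4 alone. No evidence is available that bears on this step.

Going by these compounds, whether an amine, a carboxylic acid or a longer chain on this aromatic carbon would step beyond the scatter from compound 4 remains open. Also open, on these data alone, is whether any group here can bring the number clearly away from that of compound 2 and compound 1.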